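Swapping a Thiazolyl for a Fluorophenyl on the Ring Nitrogen

The source may hold more compounds than are shown below. What is called first, only, known or untested is meant among the compounds shown, and "the series" means these compounds.

Compound 1 `CCOC(=O)c1cn(-c2nccs2)nc1CC(C)C` is the reference point of this comparison. In a toxicity assay on HepG2 2.2.15 cells (Homo sapiens) for cytotoxicity, read by CCK-8 assay, with a stated time of 8 days (a lower number here means that less compound is tolerated, a higher number that more compound is tolerated), compound 1 gives only a limit, > 100000 nM, and among the three measured values one sits at that limit (the limit of > 100000 nM in this assay, at which 1 of the 3 values shown sits). Compound 2 `CC(C)Cc1nn(-c2nccs2)cc1C(=O)Nc1ccc(F)cc1` carries a (4-fluorophenyl)amino in place of ethoxy on the carbonyl carbon; in this assay compound 2 gives 83700 nM, and the step of an at least 1.1-fold lower number from compound 1 to compound 2 (0.07 log units; that floor lies within the scatter) stays within the scatter. Compound 3 `CCOC(=O)c1cn(-c2cccc([N+](=O)[O-])c2)nc1CC(C)C` bears a nitrophenyl on the ring nitrogen instead of the thiazolyl, and in this assay compound 3 gives 59300 nM. Among the measured compounds shown here, for compound 1 and compound 3 no step is computed, and only their two values themselves can be set side by side.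

Compound 4 `CCOC(=O)c1cn(-c2ccc(F)cc2)nc1CC(C)C` differs from compound 1 by 4-fluorophenyl in place of 1,3-thiazol-2-yl on an aromatic nitrogen. For the measured compounds named here, the single measured step, from compound 1 to compound 2, changes the carbonyl side rather than the ring nitrogen and stayed within the scatter, so it offers no push in either direction. Compound 3 shows that a phenyl ring on that nitrogen can give a number rather than a limit. The estimate for compound 4 in this assay is therefore 80000 nM, with a range from 35000 nM to 150000 nM. This corresponds to an expected step of an at least 1.2-fold lower number from compound 1 to compound 4 (0.09 log units; that floor lies within the scatter), with a limit rather than a number remaining quite possible.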

Compound 4, half-maximal cytotoxic concentration: > 100000 nM
Compound 4 was reported as a limit (the forecaster's own chance of this, stated with the estimate: 45%); middle value at least 1.2-fold (0.09 log units) from the limit.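

In this assay compound 4 gives > 100000 nM as a limit and not a number. Compound 1 is also reported only as a limit, so no step between compound 1 and compound 4 can be read: the limit of > 100000 nM in this assay, at which 2 of the 4 values shown sit.

In this assay the compounds shown leave open whether 4-fluorophenyl and 1,3-thiazol-2-yl on the aromatic nitrogen differ at all.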